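Adding one methyl to an inactive amide side chain

The compounds below may be only part of what the source reports. "The series", "measured", "known", "first", "only" and "open" are said of these compounds alone.

Measured in a functional assay on PC-3 cells (Homo sapiens) for antiproliferative activity, read by MTT assay, with a stated time of 24 h; a higher number here means a weaker inhibitor, a lower number a stronger inhibitor:
Compound 1 `CCn1c(C(=O)N[C@@H](C)C(=O)OC)ccc1C(CC)(CC)c1ccc(OCS(=O)(=O)c2ccccc2)c(C)c1`: > 50000 nM, a limit
Compound 2 `CCn1c(C(=O)NCC(=O)OC)ccc1C(CC)(CC)c1ccc(OCS(=O)(=O)c2ccccc2)c(C)c1`: > 50000 nM, a limit

Compound 2 gives no number, only the limit > 50000 nM. Both measured compounds share this result: the limit of > 50000 nM in this assay, at which 2 of the 2 values shown sit. Compound 3 `CCn1c(C(=O)N[C@H](C)C(=O)OC)ccc1C(CC)(CC)c1ccc(OCS(=O)(=O)c2ccccc2)c(C)c1` arises from compound 2 by a single change, methyl in place of hydrogen on a saturated chain carbon bound to an amide-type nitrogen and a carbonyl carbon. Among the measured compounds shown here, the one measured step that bears on it exchanges the same two groups at that place: a step that the two limits leave unreadable from compound 1 to compound 2. Its size cannot be read. Compound 1, which carries a methyl there, also gives only a limit, > 50000 nM. No shift beyond the scatter is therefore expected in this assay, in either direction. The expected size is a number no higher from compound 2 to compound 3 (the limit leaves the size open). For compound 3 the estimated value is 50000 nM, with an expected range from 20000 nM to 100000 nM.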

Compound 3, half-maximal inhibitory concentration: > 50000 nM
Compound 3: only a limit was reported; the forecaster's own chance of this, stated with the estimate: 85%; the middle value sits exactly at the limit.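

Compound 3 also gives only a limit, > 50000 nM. No step among compound 1, compound 2 and compound 3 can be read, as all three share one result: the limit of > 50000 nM in this assay, at which 3 of the 3 values shown sit.

As far as these compounds go, whether the methyl or its configuration as drawn changes the potency in this assay stays open.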